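From compound 3 to compound 4: losing 1-hydroxy-1-methylethyl

The source may report more compounds than this note shows. Statements on the series, on what has been measured and on what is new or still open speak of the compounds shown alone.

Measured in an ADME assay on the whole organism (Rattus norvegicus), at a dose of 2 mg/kg by the oral route; on this read-out lower numbers stand for lower exposure and higher numbers for higher exposure at the dose given:
- compound 1 `COc1cc(OCc2cccc(-c3ccc(C(F)(F)F)cn3)c2)c2cc(-c3cn4nc(OC)sc4n3)oc2c1`: 459 ng.h/mL
- compound 2 `COc1cc(OCc2cccc(-c3cnc(OC)nc3)c2)c2cc(-c3cn4nc(OC)sc4n3)oc2c1`: 1030 ng.h/mL
- compound 3 `COc1cc(OCc2csc(-c3ccc(C(C)(C)O)cc3)n2)c2cc(-c3cn4nc(OC)sc4n3)oc2c1`: 505 ng.h/mL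

In this assay compound 3 gives 505 ng.h/mL, within the scatter of compound 1, while compound 2 stands higher, beyond the scatter. Going on to compound 4 `COc1cc(OCc2csc(-c3ccccc3)n2)c2cc(-c3cn4nc(OC)sc4n3)oc2c1` puts hydrogen in place of 1-hydroxy-1-methylethyl on an aromatic carbon. For the measured compounds named here, the one measured step, a 2.2-fold higher number from compound 1 to compound 2 (0.35 log units; beyond the scatter), was modest and exchanges other groups, so it bears only indirectly and gives no direction. No step beyond the scatter is therefore expected in this assay. The expected step is a 1.1-fold lower number from compound 3 to compound 4 (0.05 log units; within the scatter). For compound 4 the estimated value is 450 ng.h/mL, with an expected range of 170 ng.h/mL to 1200 ng.h/mL.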

Compound 4, area under the concentration-time curve: 3920 ng.h/mL
Estimate against measurement, compound 4: 8.7-fold (0.94 log units) below; the measured number lies above the stated range.
By their numbers in this assay, from the lowest: compounds 1 and 3 (each within the scatter of the next); then compound 2; then compound 4.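

Going from 4-(1-hydroxy-1-methylethyl)phenyl to phenyl gives a 7.8-fold higher number from compound 3 to compound 4 (0.89 log units; beyond the scatter) in this assay. This shows that a single substituent on the aromatic carbon para to a large group can move oral exposure in the rat well beyond the scatter, and that the bare phenyl carries the higher number of this pair. Nothing available here accounts for the rise. The compounds shown leave open whether a methyl, a methoxy or an amine at this place would keep that exposure or lose it, and so whether any group there lowers the number or only this one does.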